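Chloro to trifluoromethyl on the aryl ring

The compounds below may be only part of what the source reports. "The series", "measured", "known", "first", "only" and "open" are said of these compounds alone.

The three measured compounds share one core and differ only in the group on the aromatic ring. In an assay on isolated protein for inhibition of Dihydrofolate reductase (Mus musculus), at pH 7.20 (a higher number here means a more potent compound, by a factor of ten per unit of this negative logarithm, a lower number a less potent compound), compound 1 `CC1(C)N=C(N)N=C(N)N1c1ccccc1S` gives 6.86. Compound 2 `CC1(C)N=C(N)N=C(N)N1c1ccccc1F` gives 4.39, and compound 3 `CC1(C)N=C(N)N=C(N)N1c1ccccc1Cl` gives 4.72. Compound 3 stands second highest of the three numbers: a number 0.33 log units higher from compound 2 to compound 3 (beyond the scatter), while a number 2.14 log units lower from compound 1 to compound 3 (beyond the scatter).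

Compound 4 `CC1(C)N=C(N)N=C(N)N1c1ccccc1C(F)(F)F` is not yet measured. It differs from compound 3 in one place: trifluoromethyl in place of chloro on an aromatic carbon. Among the measured compounds shown here, no measured step carries trifluoromethyl at this position. The nearest comparison is a number 0.33 log units higher from compound 2 to compound 3 (beyond the scatter), a modest gain between two halogens. The large drops a number 2.47 log units lower from compound 1 to compound 2 (beyond the scatter) and a number 2.14 log units lower from compound 1 to compound 3 (beyond the scatter) show that the sulfanyl analogue stands far apart from both halogens, and nothing in these data places trifluoromethyl near it. A step of modest size is therefore expected for the change from chloro, most likely a small move upward, with the direction not secure. For compound 4 the expected value is 4.9, within 4.3 to 5.6, which means an expected step of a number 0.18 log units higher from compound 3 to compound 4 (within the scatter).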

Compound 4, logarithm of the reciprocal of the active concentration, log(1/C): 3.03
For compound 4 the middle estimate is 1.87 log units above the measured one; the measured number lies below the stated range.
By their numbers in this assay, from the lowest: compound 4; then compound 2; then compound 3; then compound 1.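

Trifluoromethyl does not behave as one more halogen-like step at this position, ortho to a large group: there is a fall of a number 1.69 log units lower from compound 3 to compound 4 (beyond the scatter) and, against the other halogen, a fall of a number 1.36 log units lower from compound 2 to compound 4 (beyond the scatter) in this assay. The earlier compounds shown here showed only a modest move between fluoro and chloro, whereas this single aromatic carbon now also tolerates a clear loss below both halogens, and the whole span of the series widens to a number 3.83 log units lower from compound 1 to compound 4 (beyond the scatter) with compound 4 lowest of the four. The data shown hold no independent measurement that would account for this fall.

Going by these compounds, whether the high number of compound 1 is particular to sulfanyl stays open, and a hydroxyl group or a methylsulfanyl group at this position would test that. A methyl group or an amine would show whether the fall seen with trifluoromethyl extends to other groups that are not halogens.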